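The compounds below may be only part of what the source reports. "The series", "measured", "known", "first", "only" and "open" are said of these compounds alone.

Compound 1 `CC[C@H](C)[C@H]1C(=O)N[C@H](Cc2cc(Cl)c(O)c(Cl)c2)C(=O)N[C@@H](C(C)C)C(=O)O[C@H](c2ccccc2)[C@H](C)/C=C/C=C(\C)[C@H](OC)C/C=C(\C)C(=O)N1C`: 104 nM
Compound 2 `CC[C@H](C)[C@H]1C(=O)N[C@H](Cc2ccc(O)c(Br)c2)C(=O)N[C@@H](C(C)C)C(=O)O[C@H](c2ccccc2)[C@H](C)/C=C/C=C(\C)[C@H](OC)C/C=C(\C)C(=O)N1C`: 53.7 nM
Compound 3 `CC[C@H](C)[C@H]1C(=O)N[C@H](Cc2ccc(O)c(Br)c2)C(=O)N[C@@H](C(C)(C)O)C(=O)O[C@H](c2ccccc2)[C@H](C)/C=C/C=C(\C)[C@H](OC)C[C@H]2O[C@]2(C)C(=O)N1C`: > 200 nM (a limit of the assay)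

All three were tested in a functional assay on HepG2 cells (Homo sapiens) for antiproliferative activity; on this read-out higher numbers stand for weaker inhibition and lower numbers for stronger inhibition. Compound 2 gives 53.7 nM, and compound 1 gives 104 nM; the step of a 1.9-fold higher number from compound 2 to compound 1 (0.29 log units; within the scatter) is within the usual scatter, so the two cannot be told apart. For compound 3 the read-out is > 200 nM, which is a limit of the assay and not a number. Compound 3 carries the same 3-bromo-4-hydroxyphenyl group as compound 2, but the difference between the two cores is not broken down here.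

Compound 4 `CC[C@H](C)[C@H]1C(=O)N[C@H](Cc2cc(Cl)c(O)c(Cl)c2)C(=O)N[C@@H](C(C)(C)O)C(=O)O[C@H](c2ccccc2)[C@H](C)/C=C/C=C(\C)[C@H](OC)C[C@H]2O[C@]2(C)C(=O)N1C` has not yet been measured. It stands to compound 3 exactly as compound 1 stands to compound 2: the same change, (3,5-dichloro-4-hydroxyphenyl in place of 3-bromo-4-hydroxyphenyl on a saturated chain carbon bound to a saturated ring carbon), at the same place as 3,5-dichloro-4-hydroxyphenyl in place of 3-bromo-4-hydroxyphenyl on a saturated chain carbon bound to a saturated ring carbon. The expected step in this assay is a step that the limit leaves unreadable from compound 3 to compound 4, which rests on the measured step of a 1.9-fold higher number from compound 2 to compound 1 (0.29 log units; within the scatter) being within the scatter. Compound 4 is therefore estimated at 300 nM, most likely between 150 nM and 1000 nM, with a real chance that this assay again reports only a limit.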

Compound 4, half-maximal inhibitory concentration: > 200 nM
Compound 4 was reported as a limit; the forecaster's own chance of this, stated with the estimate: 70%; the middle value does not contradict the limit.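

Compound 3 and compound 4 are both reported only as a limit in this assay, not as a number, so no step between them can be read: the limit of > 200 nM in this assay, at which 2 of the 4 values shown sit.

The compounds shown leave open what number either compound would give, and whether 3,5-dichloro-4-hydroxyphenyl in place of 3-bromo-4-hydroxyphenyl changes the read-out on this core.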